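The source may hold more compounds than are shown below. What is called first, only, known or untested is meant among the compounds shown, and "the series" means these compounds.

Compound 1 `CC1OC(n2c(=O)n(C)c3c(O)nc(N)nc32)[C@H](O)[C@@H]1O` gives 0% in a functional assay on the whole organism (B cells) with Mus musculus as the target; a higher number here means a larger maximal response, a lower number a smaller maximal response.
Compound 2 `Nc1nc(O)c2c(n1)n(C1OC(CO)[C@@H](O)[C@H]1O)c(=O)n2Cc1ccc([N+](=O)[O-])cc1` gives 147% in this assay.
Compound 3 `Cn1c(=O)n(C2OC(CO)[C@@H](O)[C@H]2O)c2nc(N)nc(O)c21` gives 99% in this assay.

Compound 3 stands second of these three in this assay: compound 2 lies nearest, with a number 48 percentage points lower from compound 2 to compound 3 (beyond the scatter), and compound 1 lies furthest, with a number 99 percentage points higher from compound 1 to compound 3 (beyond the scatter). Compound 4 `Cn1c(=O)n(C2OC(CI)[C@@H](O)[C@H]2O)c2nc(N)nc(O)c21` differs from compound 3 by iodo in place of hydroxy on a saturated chain carbon bound to a saturated ring carbon. Of the measured steps, only a number 99 percentage points higher from compound 1 to compound 3 (beyond the scatter) touches this same place and it was large; the other measured step concerns a different position. Among the measured compounds shown here, the hydroxy that entered in that step now leaves, so a downward step in this assay is expected, though iodo rather than hydrogen enters and no measured step covers that exchange. Compound 4 is therefore expected to give 40%, between 0% and 100%, with a number 59 percentage points lower from compound 3 to compound 4 (beyond the scatter) expected to lie beyond the scatter.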

Compound 4, largest response reached (reported as maximal response), in percent of the reference or control that the assay uses: 32%
For compound 4 the middle estimate is 8 percentage points above the measured one; the range from low to high includes it.
By their numbers in this assay, from the lowest: compound 1; then compound 4; then compound 3; then compound 2.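

In this assay, iodo in place of hydroxy on this saturated chain carbon gives a number 67 percentage points lower from compound 3 to compound 4 (beyond the scatter), while iodo in place of hydrogen gives a number 32 percentage points higher from compound 1 to compound 4 (beyond the scatter). The response at this place is therefore not all or nothing: iodo, with no hydrogen-bond donor or acceptor, leaves an intermediate response rather than the full loss seen with hydrogen. Nothing available accounts for this intermediate level. Going by these compounds, it remains open how an amine or a methoxy group would fare at this place, and whether iodo would have the same effect alongside the substituent that sets compound 2 apart.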